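Branching at the amine nitrogen: a shorter hydroxymethyl-bearing substituent

The source may report more compounds than this note shows. Statements on the series, on what has been measured and on what is new or still open speak of the compounds shown alone.

Measured compounds:
compound 1, `OCCCCNCc1nc2c(OCC3CCCCC3)cccc2[nH]1`, 44.3%
compound 2, `CCCC(CO)NCc1nc2c(OCC3CCCCC3)cccc2[nH]1`, 73.3%

The two compounds share one core and differ only in the group on the amine nitrogen. In an assay on cells for inhibition of interleukin-5 receptor subunit alpha (Mus musculus), read by WST assay, with a stated time of 48 h, tested at 30 uM, in the presence of a further agent that is not named here (a lower number here means less inhibition, a higher number more inhibition at the concentration tested (going by the name of the read-out)), compound 1 gives 44.3%, while compound 2 gives 73.3%. Of the two numbers compound 2 stands highest, and the step of a number 29 percentage points higher from compound 1 to compound 2 (beyond the scatter) lies beyond the scatter.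

Compound 3, `CC(C)(CO)NCc1nc2c(OCC3CCCCC3)cccc2[nH]1`, is not yet measured. Its change from compound 2 is 1-(hydroxymethyl)-1-methylethyl in place of 1-(hydroxymethyl)butyl on an amine nitrogen. Within the data shown here, the only measured step, a number 29 percentage points higher from compound 1 to compound 2 (beyond the scatter), concerns a different change, from a 4-hydroxybutyl chain to the branched 1-(hydroxymethyl)butyl group, so it bears on the present step only in that a branched group carrying a hydroxymethyl is kept in compound 3. Among the measured compounds shown here, no step shows the effect of the shorter branch itself. Compound 3 is therefore expected to stay near compound 2, with a step of a number 8.3 percentage points lower from compound 2 to compound 3 (within the scatter) that need not exceed the scatter. The estimate for compound 3 is 65%, between 45% and 85%.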

Compound 3, a percentage reported as inhibition, at one concentration (the size of the read-out at that concentration, not a potency): 54.7%
For compound 3 the middle estimate is 10.3 percentage points above the measured one; low and high end bracket the measured number.
By their numbers in this assay, from the lowest: compound 1; then compound 3; then compound 2.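

In this assay, putting 1-(hydroxymethyl)-1-methylethyl in place of 1-(hydroxymethyl)butyl on the amine nitrogen gives a number 18.6 percentage points lower from compound 2 to compound 3 (beyond the scatter) and so shows that branched groups carrying a hydroxymethyl are not interchangeable at this position. The same group still stands apart from the unbranched 4-hydroxybutyl chain, with a number 10.4 percentage points higher from compound 1 to compound 3 (beyond the scatter) in the same assay, so compound 3 keeps only part of the rise seen with compound 2 and the three compounds order as compound 1, compound 3, compound 2. No measurement offered here explains why the two branched groups differ.

The compounds shown leave open whether the lower number of compound 3 goes with the loss of the propyl part of the branch or with the two methyl groups on one carbon, as these two differences arrive together in this single change. Also open, going by these compounds, is how a 1-(hydroxymethyl)ethyl group, an isopropyl group lacking the hydroxyl, or a carboxylic acid in place of the hydroxymethyl would read on this nitrogen in this assay at the concentration tested.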